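The source may hold more compounds than are shown below. What is called first, only, known or untested is meant among the compounds shown, and "the series" means these compounds.

Compound 1 `CCOC(=O)c1cnc(N2CCN(Cc3ccccc3C(F)(F)F)CC2)nc1Oc1c(C)cc(-c2ccc(C#N)cc2)cc1C` gives > 125000 nM in an ADME assay on MT4 cells (Homo sapiens) for cytotoxicity, read by MTT assay, with a stated time of 4 days (on this read-out higher numbers stand for lower toxicity in this test and lower numbers for higher toxicity in this test), which is a limit of the assay and not a number. Compound 2 `CCOC(=O)c1cnc(N2CCN(Cc3ccc(C(=O)OC)cc3)CC2)nc1Oc1c(C)cc(-c2ccc(C#N)cc2)cc1C` gives > 125000 nM in this assay, again a limit. Compound 3 `CCOC(=O)c1cnc(N2CCN(Cc3ccccc3C(=O)OC)CC2)nc1Oc1c(C)cc(-c2ccc(C#N)cc2)cc1C` gives > 125000 nM in this assay, also a limit.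

Compound 3 therefore stands where every measured compound here stands: at the limit, since (the limit of > 125000 nM in this assay, at which 3 of the 3 values shown sit). The three measured steps tell nothing about size, because each runs between two limits: a step that the two limits leave unreadable from compound 1 to compound 2, a step that the two limits leave unreadable from compound 1 to compound 3 and a step that the two limits leave unreadable from compound 2 to compound 3.

Compound 4 `CCOC(=O)c1cnc(N2CCN(Cc3cccc([N+](=O)[O-])c3)CC2)nc1Oc1c(C)cc(-c2ccc(C#N)cc2)cc1C` differs from compound 3 in one place: 3-nitrophenyl in place of 2-(methoxycarbonyl)phenyl on a saturated chain carbon bound to an amine nitrogen in a ring. Within the data shown here, no measured step separates one benzyl substituent from another in readable numbers, so no movement beyond the scatter can be read out of the data. The expectation for compound 4 is that it stays at the limit of this assay like the three measured compounds. Compound 4 is thus estimated at 125000 nM, with a range from 60000 nM to 250000 nM. That estimate amounts to an expected step of a number no higher from compound 3 to compound 4 (the limit leaves the size open).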

Compound 4, half-maximal cytotoxic concentration: > 125000 nM
Compound 4: a limit, no number; the forecaster's own chance of this, stated with the estimate: 85%; the middle value sits exactly at the limit.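

Compound 4 sits at the same limit as compound 1, compound 2 and compound 3, so none of the steps among these four compounds can be read in size: the limit of > 125000 nM in this assay, at which 4 of the 4 values shown sit.

The compounds shown leave open the actual half-maximal cytotoxic concentration of each compound in this assay, and so whether changing the benzyl substituent alters it at all.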